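The source may hold more compounds than are shown below. What is called first, only, known or untested is meant among the compounds shown, and "the series" means these compounds.

Compound 1 `Cc1cn(C2CCN(Cc3cccc(Oc4ccccn4)c3)CC2)c(=O)[nH]c1=O`: > 64000 nM
Compound 2 `Cc1cn(C2CCN(Cc3cccc(Oc4cccc(C(F)(F)F)c4)c3)CC2)c(=O)[nH]c1=O`: 12400 nM

In an ADME assay on MRC5 cells (Homo sapiens) for cytotoxicity, read by fluorescence and resazurin assay, with a stated time of 3 days (on this read-out lower numbers stand for stronger inhibition and higher numbers for weaker inhibition), compound 1 gives > 64000 nM, which is a limit of the assay and not a number. Within the data shown here, compound 2, at 12400 nM, therefore holds the only true number so far, and nothing yet shows how it ranks against other measured values.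

The next compound, compound 3 `Cc1cn(C2CCN(Cc3cccc(Oc4cccc(OC(F)(F)F)c4)c3)CC2)c(=O)[nH]c1=O`, carries trifluoromethoxy in place of trifluoromethyl on an aromatic carbon. Among the measured compounds shown here, the group sits on the same aromatic ring that entered in the one measured step, an at least 5.1-fold lower number from compound 1 to compound 2 (0.71 log units; beyond the scatter). That step exchanged a whole ring, whereas this change only replaces a group on the ring, so it is a loose guide and suggests only that this part of the structure can matter in this assay. A change much smaller than that step is therefore expected, and the estimate stays close to compound 2, which gives 12400 nM. The expected shift is a 1.2-fold lower number from compound 2 to compound 3 (0.09 log units; within the scatter), a small estimated move towards lower numbers.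

For compound 3, the estimated value in this assay is 10000 nM, with an expected range from 4500 nM to 24000 nM.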

Compound 3, half-maximal inhibitory concentration: 5260 nM
Beside the measured number, compound 3's estimate is 1.9-fold (0.28 log units) above it, and the stated range covers the measured number.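

In this assay, the group on the aromatic carbon matters as well as the ring that carries it: trifluoromethoxy in place of trifluoromethyl gives a 2.4-fold lower number from compound 2 to compound 3 (0.37 log units; beyond the scatter), and this is the first step shown with a true number at both ends. Exchanging pyridin-2-yl for 3-(trifluoromethoxy)phenyl gives an at least 12-fold lower number from compound 1 to compound 3 (1.08 log units; beyond the scatter), so both rings with a fluorinated group now stand at lower numbers than the pyridin-2-yl compound. The size of that exchange remains open-ended, since compound 1 gives a limit of the assay and not a number: the limit of > 64000 nM in this assay, at which 1 of the 3 values shown sits.

The compounds shown leave open whether a nitrile, a chlorine, a methoxy group or a longer chain such as pentafluoroethyl on the same aromatic carbon would move the number further, stop the move or reverse it. They also leave open what lies behind the step from trifluoromethyl to trifluoromethoxy, as a single pair of true numbers cannot separate the added oxygen from the change of the group as a whole.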